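Carboxy to (dimethylamino)methyl on the chain of compound 3

The compounds below may be only part of what the source reports. "The series", "measured", "known", "first", "only" and "open" are said of these compounds alone.

Measured compounds: compound 1 `Cn1ncc(Cl)c1-c1cc(C(=O)N[C@@H]2CN[C@H](CCCO)C[C@H]2c2ccc(Cl)c(Cl)c2)oc1Cl` gives 2.56 nM; compound 2 `Cn1ncc(Cl)c1-c1cc(C(=O)N[C@@H]2CN[C@H](CCN3CCCCC3)C[C@H]2c2ccc(Cl)c(Cl)c2)oc1Cl` gives 5.65 nM; compound 3 `Cn1ncc(Cl)c1-c1cc(C(=O)N[C@@H]2CN[C@H](CC(=O)O)C[C@H]2c2ccc(Cl)c(Cl)c2)oc1Cl` gives 1.94 nM.

All three numbers come from an assay for inhibition of RAC-alpha serine/threonine-protein kinase (Homo sapiens), read by HTRF, with a stated time of 1 h; on this read-out lower numbers stand for stronger inhibition and higher numbers for weaker inhibition. Compound 3 shows the lowest number of the three, but one step, a 1.3-fold lower number from compound 1 to compound 3 (0.12 log units; within the scatter), lies within the scatter, while the other, a 2.9-fold lower number from compound 2 to compound 3 (0.46 log units; beyond the scatter), lies beyond it. Compound 4 `CN(C)CC[C@@H]1C[C@@H](c2ccc(Cl)c(Cl)c2)[C@H](NC(=O)c2cc(-c3c(Cl)cnn3C)c(Cl)o2)CN1` differs from compound 3 in that ((dimethylamino)methyl in place of carboxy on a saturated chain carbon bound to a saturated ring carbon). The step of a 2.9-fold lower number from compound 2 to compound 3 (0.46 log units; beyond the scatter) bears on this most directly, as it also exchanges a carboxy against a chain-borne amine, and the step of a 2.2-fold higher number from compound 1 to compound 2 (0.34 log units; beyond the scatter) points the same way. A modest rise in number is therefore expected, a 2.1-fold higher number from compound 3 to compound 4 (0.31 log units; beyond the scatter). Compound 4 is estimated at 4 nM in this assay, with a range from 1.6 nM to 10 nM.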

Compound 4, half-maximal inhibitory concentration: 3.4 nM
Compound 4: middle estimate off by 1.2-fold (0.07 log units), on the high side; the measured number falls inside the stated range.
By their numbers in this assay, from the lowest: compounds 3, 1, 4 and 2 (each within the scatter of the next, the first and the last beyond it).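

In this assay the change from carboxy to (dimethylamino)methyl gives a 1.8-fold higher number from compound 3 to compound 4 (0.24 log units; within the scatter) and so stays within the scatter, whereas the chain ending in piperidin-1-yl in compound 2 lay beyond the scatter of compound 3. The smaller amine also gives a 1.7-fold lower number from compound 2 to compound 4 (0.22 log units; within the scatter) and a 1.3-fold higher number from compound 1 to compound 4 (0.12 log units; within the scatter) so compound 4 lies within the scatter of each other compound. No measured evidence here accounts for these numbers.

The compounds shown leave open how a primary amine, a morpholine or a longer chain would read at this place.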